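This account rests on a few compounds, and the source may have more. Where it says the series, first, only, none or still open, it means among the compounds named here.

Measured so far in an ADME assay on PC-3 cells (Homo sapiens) for cytotoxicity, read by sulforhodamine B assay, with a stated time of 48 h, tested at 10 uM; a higher number here means more inhibition at the concentration tested (going by the name of the read-out), a lower number less inhibition:
compound 1, `COc1nc2ccc(Br)cc2cc1C(c1ccccc1)n1cc(-c2ccccc2F)nn1`: 13.4%
compound 2, `CCCCCCCCc1cn(C(c2ccccc2)c2cc3cc(Br)ccc3nc2OC)nn1`: 2.27%

Compound 2 stands lowest of the two numbers; the nearest, compound 1, lies higher, the step being a number 11.1 percentage points lower from compound 1 to compound 2 (beyond the scatter). Compound 3, `CCCCCc1cn(C(c2ccccc2)c2cc3cc(Br)ccc3nc2OC)nn1`, differs from compound 2 in one place: hydrogen in place of propyl on a saturated chain carbon, five bonds along the chain from an aromatic carbon. Within the data shown here, no measured step shortens or lengthens the chain itself; the one step known exchanges a ring for the chain, so it gives no direct bearing on this change. A step within the scatter is therefore expected, a number 2.7 percentage points higher from compound 2 to compound 3 (within the scatter). Compound 3 is expected to give 5% in this assay, between -5% and 15%.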

Compound 3, a percentage reported as inhibition, at one concentration (the size of the read-out at that concentration, not a potency): 11.4%
Beside the measured number, compound 3's estimate is 6.4 percentage points below it, and the stated range covers the measured number.
By their numbers in this assay, from the lowest: compounds 2, 3 and 1 (each within the scatter of the next, the first and the last beyond it).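

In this assay, the pentyl chain of compound 3 in place of the octyl chain of compound 2 gives a number 9.1 percentage points higher from compound 2 to compound 3 (within the scatter) and so resolves no effect of this shortening at this position. Pentyl in place of 2-fluorophenyl gives a number 2 percentage points lower from compound 1 to compound 3 (within the scatter) and thus, unlike octyl with a number 11.1 percentage points lower from compound 1 to compound 2 (beyond the scatter), does not separate from the aryl group. No evidence on hand bears on the cause of these numbers. Still open, as far as these compounds go, is whether a shorter chain, a longer chain or a terminal amine at this position would give a step beyond the scatter.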